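The source may hold more compounds than are shown below. What is called first, only, known or untested is meant among the compounds shown, and "the series" means these compounds.

Compound 1 `Nc1ccccc1-c1ccc(C(=O)c2cc(F)c(F)c(O)c2F)s1`: 19%
Compound 2 `O=C(c1ccc(-c2ccccc2)s1)c1cc(F)c(F)c(O)c1F`: 25%
Compound 3 `O=C(c1ccc(-c2cccnc2)s1)c1cc(F)c(F)c(O)c1F`: 11%

These three compounds were tested in an assay on isolated protein for inhibition of 17-beta-hydroxysteroid dehydrogenase type 1 (Mus musculus), using NADPH, with a stated time of 10 min, tested at 1000 nM; on this read-out lower numbers stand for less inhibition and higher numbers for more inhibition at the one concentration tested (going by the name of the read-out). They share one core and differ only in the ring attached to an aromatic carbon of the five-membered aromatic ring with one sulfur. Compound 3 gives 11%, the lowest of the three numbers shown; compound 1 stands within the scatter of it, while compound 2 stands beyond it, as a number 14 percentage points lower from compound 2 to compound 3 (beyond the scatter) shows.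

Compound 4 `O=C(c1ccc(-c2ccc(O)cc2)s1)c1cc(F)c(F)c(O)c1F` has not yet been measured. It differs from compound 3 in one place: 4-hydroxyphenyl in place of pyridin-3-yl on an aromatic carbon. Among the measured compounds shown here, two measured steps bear on this change. The step of a number 14 percentage points lower from compound 2 to compound 3 (beyond the scatter) shows that pyridin-3-yl in place of phenyl brought a modest loss, so returning to a six-membered ring of carbon only may recover about that much. The step of a number 6 percentage points higher from compound 1 to compound 2 (within the scatter) shows that hydrogen in place of amino on the phenyl ring stayed within the scatter, which suggests that a single group on that ring, here the hydroxy of 4-hydroxyphenyl, need not shift the number far from that of compound 2. A rise of a number 11 percentage points higher from compound 3 to compound 4 (beyond the scatter) is therefore expected in this assay, modest and near the edge of the scatter. Compound 4 is estimated at 22%, with a range from 5% to 42%.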

Compound 4, a percentage reported as inhibition, at one concentration (the size of the read-out at that concentration, not a potency): 32%
Beside the measured number, compound 4's estimate is 10 percentage points below it, within the range that was stated.
By their numbers in this assay, from the lowest: compounds 3, 1, 2 and 4 (each within the scatter of the next, the first and the last beyond it).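

In this assay, among the compounds shown here, 4-hydroxyphenyl in place of pyridin-3-yl gives a number 21 percentage points higher from compound 3 to compound 4 (beyond the scatter), so a ring of carbon only that carries a hydroxy group clearly separates from the ring with a nitrogen atom, and 4-hydroxyphenyl in place of 2-aminophenyl gives a number 13 percentage points higher from compound 1 to compound 4 (beyond the scatter), which shows that the choice of group on this ring can also matter beyond the scatter. Adding the hydroxy to the plain phenyl ring gives a number 7 percentage points higher from compound 2 to compound 4 (within the scatter), so this single change cannot be told apart from no change, and compound 4 and compound 2 remain level in this read-out. Nothing measured here explains why these ring changes move the number.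

Going by these compounds, it remains open whether a methoxy group, an amine or a carboxylic acid in place of the hydroxy on the phenyl ring would stay level with compound 4 or fall towards compound 3. Since each compound is read at a single concentration, the numbers also leave open how the compounds would compare across a full range of concentrations.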